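The compounds below may be only part of what the source reports. "The series", "measured", "known", "first", "only" and "open" are said of these compounds alone.

Compound 1 `Cc1nc(-c2cccnc2)sc1-c1nnc(Cc2ccccc2)o1` was examined in an ADME assay on HCT-116 cells (Homo sapiens) for cytotoxicity, read by MTT assay; a higher number here means that more compound is tolerated, a lower number that less compound is tolerated. In this assay compound 1 gives > 100 ug/mL, which is a limit of the assay rather than a number. Two other compounds share its core and differ only in the group on one aromatic carbon. Compound 2 `COc1ccccc1-c1nnc(-c2sc(-c3cccnc3)nc2C)o1` carries a 2-methoxyphenyl in place of the benzyl; in this assay compound 2 gives > 100 ug/mL, again a limit. Compound 3 `Cc1ccc(-c2nnc(-c3sc(-c4cccnc4)nc3C)o2)cc1` carries a 4-methylphenyl in the same position; in this assay compound 3 gives > 100 ug/mL, also a limit. The steps a step that the two limits leave unreadable from compound 1 to compound 2, a step that the two limits leave unreadable from compound 1 to compound 3 and a step that the two limits leave unreadable from compound 2 to compound 3 therefore cannot be sized. Compound 4 `Cc1ccccc1-c1nnc(-c2sc(-c3cccnc3)nc2C)o1` has not been measured yet; it differs from compound 1 in one place: 2-methylphenyl in place of benzyl on an aromatic carbon. For the measured compounds named here, the only evidence bearing on this change is the limit of > 100 ug/mL in this assay, at which 3 of the 3 values shown sit, so no step beyond the scatter is expected. Compound 4 is expected to give 120 ug/mL, with a range from 80 ug/mL to 300 ug/mL, most likely reported once more as a limit. The expected step is a step that the limit leaves unreadable from compound 1 to compound 4.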

Compound 4, half-maximal cytotoxic concentration: > 100 ug/mL
Compound 4 was reported as a limit (the forecaster's own chance of this, stated with the estimate: 85%); the middle value does not contradict the limit.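

Compound 4 is reported as a limit, as are compound 1, compound 2 and compound 3, so none of the steps between these compounds can be read: the limit of > 100 ug/mL in this assay, at which 4 of the 4 values shown sit.

The compounds shown leave open whether benzyl, 2-methoxyphenyl, 4-methylphenyl and 2-methylphenyl differ at all in this assay.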